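The compounds below may be only part of what the source reports. "The series", "measured", "known", "first", "only" and "open" are said of these compounds alone.

Compound 3 `COc1cccc2c1c(O)c(C(=O)N(C)c1ccccc1Cl)c(=O)n2C` stands lowest of the three compounds measured in a functional assay on the whole organism for inhibition, with Mus musculus as the target, at a dose of 1 mg/kg by the oral route; a lower number here means less inhibition, a higher number more inhibition at the dose given (going by the name of the read-out). In this assay compound 3 gives 50%. Its nearest neighbour is compound 2 `COc1cccc2c1c(O)c(C(=O)N(C)c1ccccc1F)c(=O)n2C`, which in this assay gives 82%, and furthest away is compound 1 `CCN(C(=O)c1c(O)c2c(Br)cccc2n(C)c1=O)c1ccccc1`, which in this assay gives 95%.

Compound 4 `COc1ccc(N(C)C(=O)c2c(O)c3c(OC)cccc3n(C)c2=O)cc1` has not yet been measured. Compared with compound 3 it differs in one place: 4-methoxyphenyl in place of 2-chlorophenyl on an amide-type nitrogen. Within the data shown here, the only measured step that touches the same part of the shared core is the one from compound 2 to compound 3, where the change was a number 32 percentage points lower from compound 2 to compound 3 (beyond the scatter). That step exchanged one halogen for another on the ring attached to the amide-type nitrogen; the change to compound 4 removes the halogen entirely and brings in a ring carrying a methoxy group, so it is a change of a different kind and the measured step gives only weak guidance. Compound 1 carries an unsubstituted phenyl on that nitrogen and gives a high value, but it differs from compound 3 in more than one place, so no single step can be read from it.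

On this basis a moderate rise is expected for compound 4, with wide uncertainty: the step from compound 3 is estimated at a number 15 percentage points higher from compound 3 to compound 4 (beyond the scatter). Compound 4 is estimated to give 65%, within a range from 35% to 90%.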

Compound 4, a percentage reported as inhibition, in the whole organism at one dose (the size of the read-out at that dose, not a potency): 84%
Compound 4: middle estimate off by 19 percentage points, on the low side; low and high end bracket the measured number.
By their numbers in this assay, from the lowest: compound 3; then compounds 2 and 4 (each within the scatter of the next); then compound 1.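

In this assay, the ring on the amide-type nitrogen does not need a halogen to give a high number: 4-methoxyphenyl in place of 2-chlorophenyl gives a number 34 percentage points higher from compound 3 to compound 4 (beyond the scatter) and so recovers what the earlier halogen swap had lost. Set against the 2-fluorophenyl ring, the same group gives a number 2 percentage points higher from compound 2 to compound 4 (within the scatter) and so cannot be ranked apart from it, which leaves the 2-chlorophenyl ring of compound 3 as the only one of these three rings on the shared core that stands apart, with the other two rings differing in both their substituent and where it sits. No measurement at hand explains why the 2-chlorophenyl ring stands apart from the other two.

The compounds shown cannot separate the effect of the kind of substituent from that of its place on the ring, since 4-chlorophenyl and 2-methoxyphenyl do not appear among them. As far as these compounds go, it also stays open how this position would respond to a ring carrying an amine or a carboxylic acid, and each number here comes from one oral dose, so it says nothing about potency.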